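The source may hold more compounds than are shown below. What is called first, only, known or untested is meant among the compounds shown, and "the series" means these compounds.

Three compounds share one core and differ only in the aryl group attached to the amide-type nitrogen. Compound 1 `O=C(Nc1ccccc1Br)N1CCN(c2ccnc(Cl)n2)CC1` gives 1070 nM in an assay on isolated protein for antagonist activity at transient receptor potential cation channel subfamily V member 1 (Homo sapiens); on this read-out higher numbers stand for weaker inhibition and lower numbers for stronger inhibition. Compound 2 `O=C(Nc1ccccc1F)N1CCN(c2ccnc(Cl)n2)CC1` gives 787 nM in this assay, and compound 3 `O=C(Nc1ccc(F)cc1)N1CCN(c2ccnc(Cl)n2)CC1` gives 1140 nM in this assay. Compound 3 therefore holds the highest of the three numbers shown, yet the gaps to its neighbours are small: a 1.1-fold higher number from compound 1 to compound 3 (0.03 log units; within the scatter), and a 1.4-fold higher number from compound 2 to compound 3 (0.16 log units; within the scatter). The exchange of one halogen for another, a 1.4-fold lower number from compound 1 to compound 2 (0.13 log units; within the scatter), likewise stays within the scatter. Compound 4 `O=C(Nc1ccc(C(F)(F)F)cc1)N1CCN(c2ccnc(Cl)n2)CC1` differs from compound 3 in one place: trifluoromethyl in place of fluoro on an aromatic carbon. Going by the values given here, none of the measured steps exchanges fluoro for trifluoromethyl, so no direct precedent exists for this change; the nearest guide is that every alteration of the aryl group seen so far has left this assay essentially where it was. On that basis the step from compound 3 to compound 4 is expected to be no larger than the usual scatter and without a clear direction, a 1.3-fold lower number from compound 3 to compound 4 (0.10 log units; within the scatter). Compound 4 is accordingly estimated to give 900 nM in this assay, with a plausible range from 300 nM to 2700 nM.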

Compound 4, half-maximal inhibitory concentration: 874 nM
Compound 4: the middle estimate sits 1.0-fold (0.01 log units) above what was measured; low and high end bracket the measured number.
By their numbers in this assay, from the lowest: compounds 2, 4, 1 and 3 (each within the scatter of the next).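

The step at this place, on an aromatic carbon para to a large group, a 1.3-fold lower number from compound 3 to compound 4 (0.12 log units; within the scatter), is the first among these compounds in which the substituent is more than a single halogen atom, and trifluoromethyl carries more heavy atoms than the fluoro it replaces. Even so, this exchange stays within the scatter in this assay, so the earlier finding that halogen exchanges and shifts on the aryl group give no readable step now extends to a substituent built on carbon. Nothing available explains why the numbers of compound 3 and compound 4 cannot be told apart, as no independent evidence bears on this result.

The compounds shown leave open whether an amine, a carboxylic acid or a longer chain at this place would give a step beyond the scatter, as every substituent here is a halogen or trifluoromethyl. They also leave open whether any other part of the shared core responds more clearly, as all four compounds differ only in the aryl group on the amide-type nitrogen.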